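This account rests on a few compounds, and the source may have more. Where it says the series, first, only, none or still open, it means among the compounds named here.

In an in vitro ADME assay on microsomes from liver (Mus musculus) for pharmacokinetics, read by LC-MS, with a stated time of 10 min, tested at 1 uM (on this read-out higher numbers stand for fast clearance and lower numbers for slow clearance), two compounds sharing one core have been measured. Compound 1 (`Cc1cc(NC(=O)[C@H]2CN(C)C[C@@H]2c2ccc(/C=C/C(=O)Nc3ccccc3N)cc2)ccc1F`) gives 62 mL/min/kg, and compound 2 (`Cc1cc(NC(=O)[C@H]2CN(C)C[C@@H]2c2ccc(/C=C/C(=O)Nc3ccccc3N)cc2)ccc1Cl`) gives 65 mL/min/kg. Within the data shown here, these two numbers lie within the usual scatter of each other, so compound 2 stands level with its only measured neighbour.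

The next compound, compound 3 (`CC(C)NC(=O)[C@H]1CN(C)C[C@@H]1c1ccc(/C=C/C(=O)Nc2ccccc2N)cc1`), keeps the shared core but alters the amide: isopropyl in place of 4-chloro-3-methylphenyl on an amide-type nitrogen. Put simply, isopropyl takes the place of 4-chloro-3-methylphenyl on an amide-type nitrogen.

Among the measured compounds shown here, the only measured step is a 1.0-fold higher number from compound 1 to compound 2 (0.02 log units; within the scatter), which is chloro in place of fluoro on an aromatic carbon, and it stays within the scatter. That swap touches one atom on a ring that now leaves entirely, so it says little about the new change. For the measured compounds named here, no measured pair tests the loss of this ring, which leaves the expectation resting on the structural change alone and calls for a wide range. A modest fall is expected, and the estimated step is a 1.6-fold lower number from compound 2 to compound 3 (0.21 log units; within the scatter). For compound 3 the expected clearance is 40 mL/min/kg, with an estimated range of 18 mL/min/kg to 80 mL/min/kg.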

Compound 3, clearance: 12 mL/min/kg
Estimate against measurement, compound 3: 3.3-fold (0.52 log units) above; the measured number lies below the stated range.
By their numbers in this assay, from the lowest: compound 3; then compounds 1 and 2 (each within the scatter of the next).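

Replacing the aryl group on the amide-type nitrogen with isopropyl moves clearance far more than the earlier halogen swap did, showing that in this assay this position matters a great deal. The drop is beyond the scatter whichever aryl compound serves as the starting point: there is a 5.4-fold lower number from compound 2 to compound 3 (0.73 log units; beyond the scatter) and also a 5.2-fold lower number from compound 1 to compound 3 (0.71 log units; beyond the scatter) in the same direction, so the fluoro and chloro compounds tell the same story. No measurement at hand explains why clearance falls with this change.

This single swap changes several things at once, removing an aromatic ring and its chloro and methyl substituents while also shortening the group to isopropyl, so the compounds shown cannot say which of these features accounts for the drop. Plain phenyl, cyclohexyl, and a longer chain such as n-butyl on the same nitrogen would help separate them, by showing whether clearance tracks the substituents, the aromatic ring, or simply the number of atoms in the group.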